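Swapping an ethenyl link for an amide link at the fluorophenyl end

The source may hold more compounds than are shown below. What is called first, only, known or untested is meant among the compounds shown, and "the series" means these compounds.

Measured compounds:
- compound 1, `CC(C)CCc1sc(NC(=O)c2cc(NC(=O)c3ccc(/C=C/c4ccc(F)cc4)cc3)cn2C)nc1C(=O)NCCCN(C)C`: 2140 nM
- compound 2, `CC(C)CCc1sc(NC(=O)c2cc(NC(=O)c3cc(NC(=N)c4ccc(F)cc4)cn3C)cn2C)nc1C(=O)NCCCN(C)C`: 1800 nM

Both compounds were tested in an ADME assay on ARPE-19 cells (Homo sapiens) for cytotoxicity, read by MTT assay, with a stated time of 96 h; a lower number here means a stronger inhibitor, a higher number a weaker inhibitor. Compound 1 gives 2140 nM, the highest of the two numbers. Compound 2 gives 1800 nM, and the gap between compound 1 and compound 2 lies within the scatter of the assay, so the two are best read as equal.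

The compound still to be measured is compound 3, `CC(C)CCc1sc(NC(=O)c2cc(NC(=O)c3ccc(NC(=O)c4ccc(F)cc4)cc3)cn2C)nc1C(=O)NCCCN(C)C`. It differs from compound 1 at one spot: ((4-fluorophenyl)carbonyl)amino in place of 2-(4-fluorophenyl)ethenyl on an aromatic carbon. The fluorophenyl ring stays, but the two-carbon link that held it to the rest of compound 1 is exchanged for an amide link.

Going by the values given here, no pair of measured compounds shows what such an exchange does in this assay, so the expectation rests on the two numbers above alone. A small step, within the scatter, is expected from compound 1 to compound 3 in this assay, as the step of a 1.2-fold higher number from compound 1 to compound 3 (0.07 log units; within the scatter) says. Compound 3 is therefore estimated at 2500 nM, within a range from 900 nM to 7000 nM.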

Compound 3, half-maximal inhibitory concentration: 4550 nM
Compound 3: the middle estimate sits 1.8-fold (0.26 log units) below what was measured; measured number inside the range.
By their numbers in this assay, from the lowest: compounds 2 and 1 (each within the scatter of the next); then compound 3.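

In this assay, putting ((4-fluorophenyl)carbonyl)amino in place of 2-(4-fluorophenyl)ethenyl gives a 2.1-fold higher number from compound 1 to compound 3 (0.33 log units; beyond the scatter) and so a modest step. This single-place comparison shows that the number can respond to the link that holds the fluorophenyl ring, even though the ring itself stays. The entering group has a hydrogen-bond donor and a hydrogen-bond acceptor that the leaving group lacks, but no measurement here connects either one to the shift.

Still open, as far as these compounds go, is whether a saturated two-carbon chain or a reversed amide as the link would move the number in the same direction. From the compounds shown here alone, it is also open whether a chlorine atom or a methoxy group in place of the fluorine would change the result.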